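Swapping an amide for a carbamate: expected clearance

A few compounds are considered here, and "the series" means these few. Any claim that something is new, unique, unknown or untested is made for them only; others in the source may bear on it.

Measured compounds:
- compound 1, `Cc1cc(C(=O)Nc2ccccc2)nn1Cc1cc(Cl)ccc1OCc1ccccc1`: "not determined" (no result reported)
- compound 2, `Cc1cc(NC(=O)C2CCOCC2)nn1Cc1cc(Cl)ccc1OCc1ccccc1`: 55 mL/min/kg
- compound 3, `Cc1cc(NC(=O)C2CCCCC2)nn1Cc1cc(Cl)ccc1OCC(C)C`: 68 mL/min/kg

The read-out here is an in vivo ADME assay on the whole organism (blood) for pharmacokinetics, with Rattus norvegicus as the target; a lower number here means slower removal, a higher number faster removal of the compound. Compound 2 gives 55 mL/min/kg in this assay, and compound 3 gives 68 mL/min/kg; the gap between these two numbers lies within the usual scatter, so the two compounds cannot be told apart, and both are removed quickly from rat blood. Compound 1 shares the same core but has no clearance number.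

Compound 4, `Cc1cc(NC(=O)OCc2ccccn2)nn1Cc1cc(Cl)ccc1OCc1ccccc1`, is the next compound to be measured. It differs from compound 2 in one place: (pyridin-2-yl)methoxy in place of oxan-4-yl on a carbonyl carbon. In plain terms, an amide becomes a carbamate, and a saturated ring gives way to an aromatic one carrying an extra hydrogen-bond acceptor. Within the data shown here, no pair of measured compounds shows this kind of change, so there is no measured step to lean on. With both measured numbers high, the expectation for this assay is a step from compound 2 to compound 4 of a 1.2-fold higher number from compound 2 to compound 4 (0.07 log units; within the scatter), which is no change beyond the scatter, with a slight lean toward faster removal. Compound 4 is therefore estimated at 65 mL/min/kg, within a range from 35 mL/min/kg to 120 mL/min/kg.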

Compound 4, clearance: 98 mL/min/kg
The estimate for compound 4 lay 1.5-fold (0.18 log units) below the measured number; low and high end bracket the measured number.
By their numbers in this assay, from the lowest: compounds 2, 3 and 4 (each within the scatter of the next).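

In this assay, replacing oxan-4-yl with (pyridin-2-yl)methoxy on a carbonyl carbon gives a 1.8-fold higher number from compound 2 to compound 4 (0.25 log units; within the scatter). Among these compounds, this is the first single-place step at this position, and it shows that turning the amide into a carbamate while exchanging a saturated ring for an aromatic one leaves compound 2 and compound 4 indistinguishable in this measurement, with neither showing slow removal. Nothing measured here explains what this change does to clearance.

As far as these compounds go, the amide-to-carbamate switch and the ring exchange arrive together, so the contribution of each remains unknown. From the compounds shown here alone, it also remains open whether a different group in this place, such as a carboxylic acid or a primary amine on a short carbon chain, would give a step beyond the scatter.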